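The source may report more compounds than this note shows. Statements on the series, on what has been measured and on what is new or still open speak of the compounds shown alone.

Of the compounds shown here, three that share one core have been measured in a functional assay on MGC-803 cells (Homo sapiens) for antiproliferative activity, read by MTT assay, with a stated time of 72 h; a higher number here means a weaker inhibitor, a lower number a stronger inhibitor. Compound 1 `CCCSc1nc(N/N=C(\C)c2ccccc2O)c2nnn(Cc3ccc(Cl)cc3)c2n1` gives 7100 nM in this assay. Compound 3 `CCCSc1nc(N/N=C/c2c(O)ccc3ccccc23)c2nnn(Cc3ccccc3)c2n1` gives 3710 nM, a number that lies within the usual scatter of that of compound 1, so the two cannot be told apart. Compound 2 `CCCSc1nc(N/N=C(\C)c2ccc(OC)cc2)c2nnn(Cc3ccccc3)c2n1` gives 44300 nM, a number beyond the scatter from compound 1 and the highest of the three. Compound 1 therefore stands second highest among the three numbers, close to compound 3 and far from compound 2.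

Compound 4 `CCCSc1nc(N/N=C(\C)c2ccccc2O)c2nnn(Cc3ccco3)c2n1` has not yet been measured. It differs from compound 1 in a single place: furan-2-yl in place of 4-chlorophenyl on a saturated chain carbon bound to an aromatic nitrogen. Among the compounds with values here, no two measured compounds differ by exactly this change, so its effect on the numbers is not known from these data. The step expected from compound 1 to compound 4 in this assay, a 1.4-fold higher number from compound 1 to compound 4 (0.15 log units; within the scatter), is a small shift toward a higher number, of a size that may not exceed the scatter. Compound 4 is estimated at 10000 nM, within a range from 3000 nM to 35000 nM.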

Compound 4, half-maximal inhibitory concentration: 4760 nM
The estimate for compound 4 lay 2.1-fold (0.32 log units) above the measured number; the measured number falls inside the stated range.
By their numbers in this assay, from the lowest: compounds 3, 4 and 1 (each within the scatter of the next); then compound 2.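

Within the data shown here, this is the first measured change at this position: in this assay furan-2-yl in place of 4-chlorophenyl on a saturated chain carbon bound to an aromatic nitrogen gives a 1.5-fold lower number from compound 1 to compound 4 (0.17 log units; within the scatter) and so the two compounds cannot be told apart. The position therefore takes a five-membered aromatic ring with one hetero atom, which brings one hydrogen-bond acceptor, in place of a chlorine-bearing six-membered carbon ring with no measurable loss in this read-out. No measurement at hand explains why the number stays within the scatter.

As far as these compounds go, it remains open whether an amine, a carboxylic acid or a longer chain in place of these rings would move the number beyond the scatter. From the compounds shown here alone, it is also open whether furan-2-yl would give so small a step if another part of the molecule were different.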